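A few compounds are considered here, and "the series" means these few. Any claim that something is new, unique, unknown or untested is made for them only; others in the source may bear on it.

Of the compounds shown here, two have been measured in a functional assay on the whole organism (strain albino) for inhibition, with Rattus norvegicus as the target, read by paw edema, with stated times of 30 min and 3 h, at a dose of 25 mg/kg by the intraperitoneal route; on this read-out higher numbers stand for more inhibition at the one dose given (going by the name of the read-out) and lower numbers for less inhibition. Compound 1, `C=C(C)C(=O)c1ccc(OC)cc1OC`, is a small open-chain ketone bearing a 2,4-dimethoxyphenyl group; in this assay compound 1 gives 31.5%. Compound 2, `COc1ccc(C2=NN(C(=O)NS(=O)(=O)c3ccc(Cl)cc3)CC2c2ccccc2)c(OC)c1`, is much larger: the same 2,4-dimethoxyphenyl group sits on a five-membered non-aromatic ring with two nitrogens, which also carries a phenyl group on a saturated ring carbon and a sulfonylurea arm. In this assay compound 2 gives 25.7%. The two numbers lie within the usual scatter of repeated measurements of each other, so the inhibition in this assay is level between them, and compound 2 does not stand apart from compound 1 on the numbers shown.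

Compound 3, `COc1ccc(C2=NN(C(=O)NS(=O)(=O)c3ccc(Cl)cc3)CC2C)c(OC)c1`, has not yet been measured. It differs from compound 2 in one place: methyl in place of phenyl on a saturated ring carbon. Among the compounds with values here, no measured pair shows what such a change does here, so there is no step to lean on. With nothing comparable on hand, the step of a number 3.7 percentage points lower from compound 2 to compound 3 (within the scatter) is expected to be small, not beyond the scatter. Compound 3 is therefore estimated at 22%, with a likely range from 10% to 35%.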

Compound 3, a percentage reported as inhibition, in the whole organism at one dose (the size of the read-out at that dose, not a potency): 16.5%
The estimate for compound 3 lay 5.5 percentage points above the measured number; the range from low to high includes it.
By their numbers in this assay, from the lowest: compounds 3, 2 and 1 (each within the scatter of the next, the first and the last beyond it).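

Within the data shown here, this pair is the first direct test of the saturated ring carbon next to the ring atom that bears a 2,4-dimethoxyphenyl group, and in this assay replacing phenyl with methyl there gives a number 9.2 percentage points lower from compound 2 to compound 3 (within the scatter). Although a six-membered aromatic ring of six carbons gives way to a single carbon, the step stays within the usual scatter, so this pair does not show that the phenyl group is needed for the inhibition seen at this one dose; a real but modest loss also cannot be ruled out from one pair, since the step is a sizeable one that still falls inside the scatter. No measurement on hand explains the size of this step or says what either group does at this position.

Going by these compounds, whether an ethyl group, a longer chain or an amine on the same ring carbon would give a step beyond the scatter remains open. On these data alone, it is also open whether the swap from phenyl to methyl would look the same at other doses, where the read-out might separate the compounds more clearly.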